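Swapping the Benzyl Group on a Shared Core

The compounds below may be only part of what the source reports. "The series", "measured", "known", "first", "only" and "open" are said of these compounds alone.

Of the compounds shown here, three built on one shared core have been tested in a functional assay on A549 cells (Homo sapiens) for cytotoxicity, read by MTT assay, with a stated time of 72 h; a higher number here means a weaker inhibitor, a lower number a stronger inhibitor. Compound 1 `CC1CCN(Cc2ccc3nc(NC(=O)N/N=C/c4cn(Cc5ccc(Cl)cc5Cl)c5ccccc45)sc3c2)CC1` gives 3640 nM. Compound 2 `CC1CCN(Cc2ccc3nc(NC(=O)N/N=C/c4cn(Cc5ccccc5Cl)c5ccccc45)sc3c2)CC1` gives 3330 nM, the second highest of the three numbers; it sits close to compound 1, with a change of hydrogen in place of chloro on an aromatic carbon giving a 1.1-fold lower number from compound 1 to compound 2 (0.04 log units; within the scatter). Compound 3 `CN(C)Cc1ccc2nc(NC(=O)N/N=C/c3cn(Cc4ccccc4Cl)c4ccccc34)sc2c1` gives 1080 nM, and the change of dimethylamino in place of 4-methylpiperidin-1-yl on a saturated chain carbon bound to an aromatic carbon gave a 3.1-fold lower number from compound 2 to compound 3 (0.49 log units; beyond the scatter).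

Compound 4 `CC1CCN(Cc2ccc3nc(NC(=O)N/N=C/c4cn(Cc5ccc(C(C)(C)C)cc5)c5ccccc45)sc3c2)CC1` has not yet been measured. It differs from compound 2 in one place: 4-(tert-butyl)phenyl in place of 2-chlorophenyl on a saturated chain carbon bound to an aromatic nitrogen. Going by the values given here, only one measured step touches this same benzyl group, the one between compound 1 and compound 2, and it stayed within the scatter. The step from compound 2 to compound 3 alters a different part of the molecule and so says little here. Because the step at this group, a 1.1-fold lower number from compound 1 to compound 2 (0.04 log units; within the scatter), barely moved the number, compound 4 is expected to show a 1.1-fold lower number from compound 2 to compound 4 (0.05 log units; within the scatter), a small step at most in either direction. The number for compound 4 is therefore estimated near 3000 nM, within a range from 1200 nM to 8000 nM.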

Compound 4, half-maximal inhibitory concentration: 3710 nM
For compound 4 the middle estimate is 1.2-fold (0.09 log units) below the measured one; low and high end bracket the measured number.
By their numbers in this assay, from the lowest: compound 3; then compounds 2, 1 and 4 (each within the scatter of the next).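

In this assay, replacing 2-chlorobenzyl with 4-(tert-butyl)benzyl gives a 1.1-fold higher number from compound 2 to compound 4 (0.05 log units; within the scatter), and replacing the 2,4-dichlorophenyl group at the same place with 4-(tert-butyl)phenyl gives a 1.0-fold higher number from compound 1 to compound 4 (0.01 log units; within the scatter). Until now, this position had been probed only by adding or removing one chloro group, whereas here a group of 10 heavy atoms, all carbon, replaces one of 7 heavy atoms that includes chlorine, and the chlorine-free compound 4 still cannot be told apart from compound 1 or compound 2. Among these three compounds, all of which carry 4-methylpiperidin-1-yl, the change of benzyl group therefore leaves the number within the scatter, but no measurement shown here offers an explanation for this.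

Still open, going by these compounds, is whether this flat picture would hold for a benzyl group carrying an amine or a carboxylic acid, or for a longer chain on the aromatic nitrogen in place of the benzyl group. Going by these compounds alone, also open is whether 4-(tert-butyl)benzyl would behave the same way alongside the dimethylamino group of compound 3, the only change so far to move the number beyond the scatter.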